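This account rests on a few compounds, and the source may have more. Where it says the series, first, only, none or still open, it means among the compounds named here.

Compound 1 `N#Cc1ccc(Cn2c(/C=C3\SC(=S)N(CC(=O)O)C3=O)nc3ccccc32)cc1` gives 9780 nM in a functional assay on Raji cells (Homo sapiens) for cytotoxicity, read by MTT assay, with a stated time of 48 h; on this read-out higher numbers stand for weaker inhibition and lower numbers for stronger inhibition
Compound 2 `O=C(O)CN1C(=O)/C(=C/c2nc3ccccc3n2Cc2ccccc2)SC1=S` gives 3860 nM in this assay

Of these two, compound 1 has the higher number and so the weaker inhibition. Going by the values given here, the one measured step, with hydrogen in place of cyano on an aromatic carbon, is a 2.5-fold lower number from compound 1 to compound 2 (0.40 log units; beyond the scatter) and it is modest.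

Compound 3 `O=C(O)CN1C(=O)/C(=C/c2nc3ccccc3n2Cc2ccc(C(F)(F)F)cc2)SC1=S` has not yet been measured. It shares the core of compound 1 but has trifluoromethyl in place of cyano on an aromatic carbon, para to a large group (trifluoromethyl in place of cyano on an aromatic carbon). The measured step bears on this change only in part. Among the compounds with values here, compound 2, at 3860 nM, shows what happens when the cyano leaves and only hydrogen enters, and no measured compound carries trifluoromethyl. A small move towards a lower number in this assay is therefore expected, perhaps none beyond the scatter. The expected change is a 1.5-fold lower number from compound 1 to compound 3 (0.18 log units; within the scatter). For compound 3 the estimated value is 6500 nM, with an expected range from 2800 nM to 14000 nM.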

Compound 3, half-maximal inhibitory concentration: 18800 nM
The estimate for compound 3 lay 2.9-fold (0.46 log units) below the measured number, outside the stated range (above it).
By their numbers in this assay, from the lowest: compound 2; then compounds 1 and 3 (each within the scatter of the next).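

In this assay, trifluoromethyl in place of cyano gives a 1.9-fold higher number from compound 1 to compound 3 (0.28 log units; within the scatter), so on this carbon of the benzyl-bearing ring, para to a large group, this read-out cannot tell the two groups apart. Against hydrogen the result is clearer: trifluoromethyl in place of hydrogen gives a 4.9-fold higher number from compound 2 to compound 3 (0.69 log units; beyond the scatter), which means that the gap first seen with cyano is not confined to cyano, and compound 2, with hydrogen, now has the lowest number of the three, beyond the scatter from both others. Nothing measured here gives a reason for these differences.

With only hydrogen, cyano and trifluoromethyl at this place, the compounds shown leave open whether any group on this carbon can match hydrogen, for instance an amine, a methoxy group or a single fluorine atom. They also leave open whether cyano or trifluoromethyl would give similar numbers on a different carbon of the same ring, and whether the same trend would hold if the carboxylic acid side chain of the shared core were replaced by a longer chain.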